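The source may report more compounds than this note shows. Statements on the series, on what has been measured and on what is new or still open speak of the compounds shown alone.

Four nucleoside analogues built on one shared core are compared here, and three of them have been tested for cytotoxicity. Compound 1 `OC[C@H]1O[C@@H](n2cc(F)c3c(-c4ccoc4)ncnc32)[C@H](O)[C@@H]1O` carries a furan-3-yl group and a fluoro group. In a functional assay on HL-60 cells (Homo sapiens) for cytotoxicity, read by XTT assay, with a stated time of 3 days (a lower number here means a stronger inhibitor, a higher number a weaker inhibitor), compound 1 gives 2000 nM. Compound 2 `OC[C@H]1O[C@@H](n2cc(F)c3c(-c4ccsc4)ncnc32)[C@H](O)[C@@H]1O` differs from compound 1 only by thiophen-3-yl in place of furan-3-yl on an aromatic carbon. In this assay compound 2 gives 4900 nM, which is a 2.5-fold higher number from compound 1 to compound 2 (0.39 log units; beyond the scatter). Compound 3 `OC[C@H]1O[C@@H](n2cc(Cl)c3c(-c4ccoc4)ncnc32)[C@H](O)[C@@H]1O` differs from compound 1 by chloro in place of fluoro on an aromatic carbon, and in this assay compound 3 gives 2500 nM, a difference of a 1.3-fold higher number from compound 1 to compound 3 (0.10 log units; within the scatter), so the two halogen variants cannot be told apart on this evidence.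

Compound 4 `OC[C@H]1O[C@@H](n2cc(Cl)c3c(-c4ccsc4)ncnc32)[C@H](O)[C@@H]1O` has not yet been tested. Its relation to compound 3 is thiophen-3-yl in place of furan-3-yl on an aromatic carbon, the same change that separates compound 2 from compound 1; the surroundings of the exchanged group are the same in both pairs, while the two cores differ only by the halogen just described. Because the step from compound 1 to compound 2 was a 2.5-fold higher number from compound 1 to compound 2 (0.39 log units; beyond the scatter), the same change is expected to cost about as much again, and the step from compound 3 to compound 4 is estimated at a 2.4-fold higher number from compound 3 to compound 4 (0.38 log units; beyond the scatter). On that basis, compound 4 is expected to give about 6000 nM in this assay. Among the measured compounds shown here, the estimate for compound 4 is expected to fall between 3000 nM and 12000 nM, the width reflecting that a single earlier step is the only guide.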

Compound 4, half-maximal inhibitory concentration: 1600 nM
Estimate against measurement, compound 4: 3.8-fold (0.57 log units) above; measured number below the stated range.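

In this assay, the exchange of furan-3-yl for thiophen-3-yl on the chloro core gives a 1.6-fold lower number from compound 3 to compound 4 (0.19 log units; within the scatter), so compound 3 and compound 4 cannot be told apart, and the clear step seen on the fluoro core does not carry over: the same change on two cores in this assay, a 2.5-fold higher number (0.39 log units; beyond the scatter) from compound 1 to compound 2 and a 1.6-fold lower number (0.19 log units; within the scatter) from compound 3 to compound 4, 3.8-fold (0.58 log units) apart, beyond the scatter of two such steps

Read the other way, chloro in place of fluoro gives a 3.1-fold lower number from compound 2 to compound 4 (0.49 log units; beyond the scatter) when thiophen-3-yl is present, whereas the two halogen variants carrying furan-3-yl could not be told apart: the same change on two cores in this assay, a 1.3-fold higher number (0.10 log units; within the scatter) from compound 1 to compound 3 and a 3.1-fold lower number (0.49 log units; beyond the scatter) from compound 2 to compound 4, 3.8-fold (0.58 log units) apart, beyond the scatter of two such steps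

Within these four compounds, then, the effect of a change at one place depends on the group at the other, but four numbers do not show why this happens or whether it would hold for any other pair of groups.

The compounds shown leave open how the exchange would behave with a bromo group or a plain hydrogen in place of the halogen. They also leave open what a phenyl ring or an amine would do in place of furan-3-yl or thiophen-3-yl, and whether the same dependence would appear outside this assay.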